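Working notes: compound 1 to compound 4 in this series

A few compounds are considered here, and "the series" means these few. Any claim that something is new, unique, unknown or untested is made for them only; others in the source may bear on it.

Of the compounds shown here, three of the shared core have been tested in a functional assay on K562 cells (Homo sapiens) for cytotoxicity, with a stated time of 72 h; a higher number here means a weaker inhibitor, a lower number a stronger inhibitor. Compound 1 `CC(C)[C@H](NC(=O)c1cc(Cl)ccc1O)C(=O)Nc1ccc(Cl)cc1` returns only a limit in this assay, > 20000 nM. Compound 2 `O=C(CNC(=O)c1cc(Cl)ccc1O)Nc1cccc(Cl)c1` likewise gives only a limit, > 10000 nM. Compound 3 `C[C@H](NC(=O)c1ccc(Cl)cc1O)C(=O)Nc1ccc(C(F)(F)F)cc1` also stops at a limit, > 12500 nM. Going by the values given here, none of the three yields a number; each sits at its own limit, the limit of > 20000 nM in this assay, at which 1 of the 3 values shown sits, for compound 1, the limit of > 10000 nM in this assay, at which 1 of the 3 values shown sits, for compound 2 and the limit of > 12500 nM in this assay, at which 1 of the 3 values shown sits, for compound 3, so compound 1 cannot be placed in order against the others, and no step between measured compounds can be read off.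

Compound 4 `COc1ccc(NC(=O)[C@@H](NC(=O)c2cc(Cl)ccc2O)C(C)C)cc1` is not yet measured. It differs from compound 1 by methoxy in place of chloro on an aromatic carbon, para to a large group. Among the compounds with values here, with compound 1 at a limit in this assay there is no measured step to draw on; the expectation is a step no larger than the scatter, a step that the limit leaves unreadable from compound 1 to compound 4, in no particular direction, with the result most likely again reported as a limit. Compound 4 is therefore expected to give 30000 nM in this assay, with a range from 8000 nM to 120000 nM.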

Compound 4, half-maximal inhibitory concentration: > 10000 nM
Compound 4 gave a limit, no number; the forecaster's own chance of this, stated with the estimate: 85%; the middle value does not contradict the limit.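

Going by these compounds alone, compound 1 and compound 4 both return only limits in this assay, and no step between them can be read for methoxy in place of chloro on an aromatic carbon. The compounds shown leave open whether any compound of the shared core gives a number in this assay, and what size the change from 4-chlorophenyl to 4-methoxyphenyl has.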